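A few compounds are considered here, and "the series" means these few. Any claim that something is new, unique, unknown or untested is made for them only; others in the source may bear on it.

Compound 1 `CCCCCCCCS(=O)(=O)Nc1cc(-c2ccccc2Cl)ccc1C(=O)O` and compound 2 `CCCCCCCCS(=O)(=O)Nc1cc(-c2ccc(OC)cc2)ccc1C(=O)O` share one core and differ only in the aryl group on an aromatic carbon. In an assay on mitochondria (strain BALB/c) for inhibition of glycerol-3-phosphate acyltransferase 1, mitochondrial (Mus musculus), read by scintillation counting, with a stated time of 10 min (a higher number here means a weaker inhibitor, a lower number a stronger inhibitor), compound 1 gives 26900 nM, and compound 2 gives 13300 nM, the lowest of the two numbers seen so far; the step of a 2.0-fold lower number from compound 1 to compound 2 (0.31 log units; beyond the scatter) is modest. Compound 3 `CCCCCCCCS(=O)(=O)Nc1cc(-c2cccc(F)c2)ccc1C(=O)O` carries 3-fluorophenyl in place of 4-methoxyphenyl on an aromatic carbon. Of the measured steps only a 2.0-fold lower number from compound 1 to compound 2 (0.31 log units; beyond the scatter) touches this aryl group, and it was small. For compound 3 a step of similar size or none beyond the scatter is therefore expected, a 1.5-fold higher number from compound 2 to compound 3 (0.18 log units; within the scatter). Compound 3 is estimated at 20000 nM, within 8000 nM to 50000 nM.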

Compound 3, half-maximal inhibitory concentration: 32600 nM
For compound 3 the middle estimate is 1.6-fold (0.21 log units) below the measured one; the measured number falls inside the stated range.
By their numbers in this assay, from the lowest: compound 2; then compounds 1 and 3 (each within the scatter of the next).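

With 3-fluorophenyl in place of 4-methoxyphenyl, this assay gives a second modest step at this position, beyond the scatter (a 2.5-fold higher number from compound 2 to compound 3 (0.39 log units; beyond the scatter)). The step between the two halogen-bearing aryl groups stays within the scatter (a 1.2-fold higher number from compound 1 to compound 3 (0.08 log units; within the scatter)), so 4-methoxyphenyl alone stands apart among the three, with the lowest number. No measurement here bears on the reason for this difference.

Open, from the compounds shown here alone, is whether the methoxy group itself or its place on the ring sets compound 2 apart, since the aryl groups differ in both. Also open, going by these compounds, is how an amine or a nitrile on this aryl ring would compare with compound 2.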